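Benzylation of the ring amine, second hydroxy arrangement

A few compounds are considered here, and "the series" means these few. Any claim that something is new, unique, unknown or untested is made for them only; others in the source may bear on it.

Compound 3 `OC1CCNCC1N1CCN(c2ccccc2)CC1` stands in an assay on PC-12 cells for displacement of a labelled ligand from vesicular acetylcholine transporter (Homo sapiens) (on this read-out higher numbers stand for weaker inhibition and lower numbers for stronger inhibition), at a limit only. In this assay compound 3 gives > 100 nM, which is a limit of the assay and not a number. Compound 1 `OC1CNCCC1N1CCN(c2ccccc2)CC1` carries the hydroxy group and the large group on the shared core in the other arrangement, and in this assay compound 1 gives 100 nM. Compound 2 `OC1CN(Cc2ccc(Br)cc2)CCC1N1CCN(c2ccccc2)CC1` is the benzylated counterpart of compound 1; in this assay compound 2 gives > 100 nM, again a limit. Among the measured compounds shown here, the one measured step with the same change is a number no lower from compound 1 to compound 2 (the limit leaves the size open), whose size stays open because the limit of > 100 nM in this assay, at which 2 of the 3 values shown sit, sets where two of the three values sit. Compound 4 `OC1CCN(Cc2ccc(Br)cc2)CC1N1CCN(c2ccccc2)CC1` is to be measured in this assay. The change is 4-bromobenzyl in place of hydrogen on an amine nitrogen in a ring. For the measured compounds named here, compound 3 already sits at the limit, and the one comparable step did not lower the number, so no step toward stronger inhibition is expected. The step that the limit leaves unreadable from compound 3 to compound 4 is expected to be none beyond the scatter or upward. For compound 4 the estimate in this assay is 400 nM, with a range from 100 nM to 3000 nM.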

Compound 4, half-maximal inhibitory concentration: > 100 nM
Compound 4: only a limit was reported; the forecaster's own chance of this, stated with the estimate: 80%; the middle value is on the limit's open side.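

In this assay compound 4 gives > 100 nM, a limit and not a number. No step can be read from compound 3 to compound 4, as both stand at the same limit: the limit of > 100 nM in this assay, at which 3 of the 4 values shown sit. The compounds shown leave open whether 4-bromobenzyl in place of hydrogen on an amine nitrogen in a ring changes the number here at all.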